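Thiazolylmethyl Amine Variant in a Series Without Measured Cytotoxicity

A few compounds are considered here, and "the series" means these few. Any claim that something is new, unique, unknown or untested is made for them only; others in the source may bear on it.

Three compounds have so far been run in an ADME assay on HEK293 cells (Homo sapiens) for cytotoxicity, read by ATP content, with a stated time of 6 h; on this read-out higher numbers stand for lower toxicity in this test and lower numbers for higher toxicity in this test. Compound 1 `CCCCNc1nc(N)nc2ccn(Cc3ccccc3)c12` returns only a limit of the assay, > 24000 nM, and not a number. Compound 2 `CCCCNc1nc(N)nc2ccn(Cc3cn4ccccc4n3)c12` likewise returns a limit, > 24000 nM. Compound 3 `CCOCCNc1nc(N)nc2ccn(Cc3ccccn3)c12` also returns a limit, > 24000 nM. Within the data shown here, compound 3 therefore stands level with the others, all three resting at the limit of > 24000 nM in this assay, at which 3 of the 3 values shown sit, and no step between measured compounds can be read. Compound 4 `Nc1nc(NCc2nccs2)c2c(ccn2Cc2ccccn2)n1` differs from compound 3 by 1,3-thiazol-2-yl in place of ethoxymethyl on a saturated chain carbon bound to a nitrogen on an aromatic ring. Since every measured value is a limit, the step that the limit leaves unreadable from compound 3 to compound 4 is expected to be none beyond the scatter, with compound 4 again at the limit. The estimate for compound 4 in this assay is 30000 nM, expected to lie between 12000 nM and 100000 nM.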

Compound 4, half-maximal cytotoxic concentration: > 24000 nM
Compound 4: only a limit was reported; the forecaster's own chance of this, stated with the estimate: 80%; the middle value is on the limit's open side.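

Compound 4 returns only a limit, > 24000 nM. Among these compounds, compound 3 also rests at a limit, and no step from compound 3 to compound 4 can be read. The compounds shown leave open at what concentration any of them becomes cytotoxic, and whether 1,3-thiazol-2-yl in place of ethoxymethyl alters that concentration.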